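Widening the amine ring at the end of the chain

The source may hold more compounds than are shown below. What is called first, only, known or untested is meant among the compounds shown, and "the series" means these compounds.

Compound 1 `COc1cc2c(Oc3ccc(NC(=O)c4nn(-c5ccccc5F)c(=O)c5ccccc45)cc3F)ccnc2cc1OCCCN1CCCC1` gives 140 nM in a functional assay on MKN-45 cells (Homo sapiens) for cytotoxicity, read by MTT assay, with a stated time of 72 h (a lower number here means a stronger inhibitor, a higher number a weaker inhibitor), the lowest of the two numbers at hand; compound 2 `COc1cc2c(Oc3ccc(NC(=O)c4nn(-c5ccc([N+](=O)[O-])cc5)c(=O)c5ccccc45)cc3F)ccnc2cc1OCCCN1CCCC1` gives 1620 nM in this assay, and the step of a 12-fold higher number from compound 1 to compound 2 (1.06 log units; beyond the scatter) is large. Compound 3 `COc1cc2c(Oc3ccc(NC(=O)c4nn(-c5ccccc5F)c(=O)c5ccccc45)cc3F)ccnc2cc1OCCCN1CCC(C)CC1` differs from compound 1 elsewhere: 4-methylpiperidin-1-yl in place of pyrrolidin-1-yl on a saturated chain carbon, three bonds along the chain from an oxygen on an aromatic ring. No measured step touches this part of the molecule, so nothing shown tells how this assay answers such a change. The step expected in this assay, no change at the digits printed from compound 1 to compound 3 (within the scatter), is none beyond the scatter. Compound 3 is estimated at 140 nM, between 50 nM and 400 nM.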

Compound 3, half-maximal inhibitory concentration: 260 nM
The estimate for compound 3 lay 1.9-fold (0.27 log units) below the measured number; measured number inside the range.
By their numbers in this assay, from the lowest: compounds 1 and 3 (each within the scatter of the next); then compound 2.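

At this end of the molecule, the first change shown in this assay gives a 1.9-fold higher number from compound 1 to compound 3 (0.27 log units; within the scatter). Swapping pyrrolidin-1-yl for the larger 4-methylpiperidin-1-yl on the chain therefore leaves the cell result unchanged within the usual scatter. Nothing available explains this result.

The ring and the methyl change together in this single step, so the part played by each remains unseparated. Going by these compounds, whether a morpholine ring, a dimethylamino group or a longer chain would fare as well remains open.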